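The source may hold more compounds than are shown below. What is called first, only, known or untested is meant among the compounds shown, and "the series" means these compounds.

Measured compounds:
compound 1, `O=[N+]([O-])c1ccccc1-c1nc2cc(C(F)(F)F)ccc2[nH]1`: 15000 nM
compound 2, `COc1ccccc1-c1nc2cc(C(F)(F)F)ccc2[nH]1`: 575000 nM

In a functional assay on aorta (Rattus norvegicus, strain Wistar) for inhibition, with a stated time of 60 min (on this read-out lower numbers stand for an effect already at smaller amounts and higher numbers for an effect only at larger amounts of compound), compound 2 gives 575000 nM, the higher of the two numbers; its nearest neighbour is compound 1 with 15000 nM, and the step of a 38-fold higher number from compound 1 to compound 2 (1.58 log units; beyond the scatter) goes with methoxy in place of nitro on an aromatic carbon. Compound 3, `CCOc1ccccc1-c1nc2cc(C(F)(F)F)ccc2[nH]1`, differs from compound 2 by methyl in place of hydrogen on a saturated chain carbon bound to an oxygen on an aromatic ring; read one bond further out, this is methoxy to ethoxy. Among the measured compounds shown here, no measured step touches a saturated chain carbon bound to an oxygen on an aromatic ring; the only step known, a 38-fold higher number from compound 1 to compound 2 (1.58 log units; beyond the scatter), exchanges the whole group on the aromatic carbon and does not bear on lengthening the chain by a methyl. With nothing to lean on, no step beyond the scatter is expected in this assay for compound 3, in either direction. Compound 3 is therefore estimated at 500000 nM, with a range from 150000 nM to 2000000 nM, which means an expected step of a 1.2-fold lower number from compound 2 to compound 3 (0.06 log units; within the scatter).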

Compound 3, half-maximal effective concentration: 549000 nM
Beside the measured number, compound 3's estimate is 1.1-fold (0.04 log units) below it, and the stated range covers the measured number.
By their numbers in this assay, from the lowest: compound 1; then compounds 3 and 2 (each within the scatter of the next).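

Methyl in place of hydrogen on a saturated chain carbon bound to an oxygen on an aromatic ring, methoxy to ethoxy, gives the first reading of this chain carbon in this assay (a 1.0-fold lower number from compound 2 to compound 3 (0.02 log units; within the scatter)), a step within the scatter, so compound 2 and compound 3 cannot be told apart here. Exchanging nitro for ethoxy on the aromatic carbon gives a large step (a 37-fold higher number from compound 1 to compound 3 (1.56 log units; beyond the scatter)), as methoxy did (a 38-fold higher number from compound 1 to compound 2 (1.58 log units; beyond the scatter)), so the large step away from compound 1 is no longer tied to methoxy alone. Nothing measured on these compounds accounts for either step.

Open, as far as these compounds go, is whether a longer chain such as propoxy still reads alongside compound 2 and compound 3. Also open, from the compounds shown here alone, is whether an amine or a carboxylic acid in place of nitro on the aromatic carbon would stand closer to compound 1 (15000 nM) or to the alkoxy pair.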